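The source may report more compounds than this note shows. Statements on the series, on what has been measured and on what is new or still open speak of the compounds shown alone.

Working notes on the series.

Compound 1 `COc1cc(Cl)nc2n/c(=N/C(=O)c3c(-c4ccc(Cl)cc4Cl)noc3C)sn12` is the reference point. Going by the values given here, in a functional assay on the whole organism for inhibition, with Digitaria ciliaris as the target, with a stated time of 72 h, tested at 100 mg/L (on this read-out higher numbers stand for more inhibition of growth at the one concentration tested and lower numbers for less inhibition of growth), compound 1 gives 72.8%, the highest of the three numbers measured so far. Compound 3 `Cc1onc(-c2ccc(Cl)cc2Cl)c1C(=O)/N=c1/nc2nc(Cl)cc(C)n2s1` stands nearest: in this assay compound 3 gives 68.1%, and the step of a number 4.7 percentage points lower from compound 1 to compound 3 (within the scatter) lies within the scatter. Compound 2 `COc1cc(Cl)nc(NC(=S)NC(=O)c2c(-c3ccc(Cl)cc3Cl)noc2C)n1`, the open-chain relative, stands furthest: in this assay compound 2 gives 62.2%, a number beyond the scatter below compound 1.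

Compound 4 `COc1cc(C)nc2n/c(=N/C(=O)c3c(-c4ccc(Cl)cc4Cl)noc3C)sn12` is not yet measured. It differs from compound 1 as follows: methyl in place of chloro on an aromatic carbon. Among the compounds with values here, no measured step matches this exact exchange of chloro for methyl on that carbon. Within the data shown here, the only measured step on the same ring of the shared core, a number 4.7 percentage points lower from compound 1 to compound 3 (within the scatter), concerns methyl in place of methoxy at a different carbon and stayed within the scatter. By that single precedent a small exchange of one heavy atom for another on this ring is expected to move this assay little, in no clear direction beyond the scatter; the drop to compound 2 does not bear on it, since compound 2 lacks the fused ring altogether.

The estimated step is a number 4.8 percentage points lower from compound 1 to compound 4 (within the scatter), within the scatter. Compound 4 is therefore expected to give about 68% in this assay, within the range 54% to 80%.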

Compound 4, percent growth inhibition at one concentration: 80.6%
The estimate for compound 4 lay 12.6 percentage points below the measured number; the whole stated range lies below it.
By their numbers in this assay, from the lowest: compounds 2, 3, 1 and 4 (each within the scatter of the next, the first and the last beyond it).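

Going by these compounds alone, the exchange of chloro for methyl on the aromatic carbon next to the ring nitrogen, meta to a methoxy group, gives in this assay a number 7.8 percentage points higher from compound 1 to compound 4 (within the scatter), the first reading at this position. Chloro at this carbon is therefore not needed to hold the growth inhibition of compound 1, since methyl, with the same count of one heavy atom, keeps the read-out within the scatter. The other exchange on this ring, a number 4.7 percentage points lower from compound 1 to compound 3 (within the scatter), is also within the scatter, so the two steps point in opposite directions on paper but neither sets a direction, and nothing measured here explains either step.

The compounds shown leave open how this position responds to a group of a different kind, such as an amine, or to a longer chain such as ethyl, since chloro and methyl are the only groups seen there. They also leave open whether methyl at this carbon would read the same with a second methyl in place of the methoxy group, or on the open-chain relative compound 2.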